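Hydroxy Added to the Anilino Ring of Compound 3

This account rests on a few compounds, and the source may have more. Where it says the series, first, only, none or still open, it means among the compounds named here.

Three compounds sharing one core were tested in a functional assay on the whole organism (strain albino) for inhibition, with Rattus norvegicus as the target, read by paw edema, with stated times of 1 h and 3 h, at a dose of 100 mg/kg by the oral route; a higher number here means a stronger effect of the compound at the dose given, a lower number a weaker effect. Compound 1, `O=C(CSc1nc(-c2ccc(Cl)cc2)c(C(=O)O)c(=O)[nH]1)Nn1c(COc2ccc(Cl)cc2Cl)nc2ccccc2c1=O`, gives 61.4%. Compound 2, `N#Cc1c(Cl)nc(SCC(=O)Nn2c(COc3ccc(Cl)cc3Cl)nc3ccccc3c2=O)nc1-c1ccc(Cl)cc1`, gives 68.4% in this assay. Compound 3, `N#Cc1c(Nc2ccccc2)nc(SCC(=O)Nn2c(COc3ccc(Cl)cc3Cl)nc3ccccc3c2=O)nc1-c1ccccc1`, gives 78.1% in this assay, the highest of the three numbers; its gap to compound 2 lies within the usual scatter, so no order between these two can be read, while its gap to compound 1 lies beyond the scatter.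

Compound 4, `N#Cc1c(Nc2ccc(O)cc2)nc(SCC(=O)Nn2c(COc3ccc(Cl)cc3Cl)nc3ccccc3c2=O)nc1-c1ccccc1`, has not yet been measured. It differs from compound 3 in a single place: hydroxy in place of hydrogen on an aromatic carbon. Among the measured compounds shown here, no measured pair in this set differs in the same way, so no step exists from which the effect of a hydroxy entering for hydrogen could be read. The three values that do exist lie close together even though the compounds differ in larger ways elsewhere, and that gives no reason to expect a large movement here. For compound 4 the expected step is a number 2.1 percentage points lower from compound 3 to compound 4 (within the scatter), within the scatter and in no clear direction. Compound 4 is therefore estimated to give about 76% in this assay, with a range from 63% to 87%.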

Compound 4, a percentage reported as inhibition, in the whole organism at one dose (the size of the read-out at that dose, not a potency): 59.7%
Estimate against measurement, compound 4: 16.3 percentage points above; measured number outside the range, below it.
By their numbers in this assay, from the lowest: compounds 4, 1, 2 and 3 (each within the scatter of the next, the first and the last beyond it).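

In this assay, among the compounds shown here, compound 3 and compound 4 form the only pair in the set that differs in one place, so the effect of a single change can now be read: going from anilino to (4-hydroxyphenyl)amino gives a number 18.4 percentage points lower from compound 3 to compound 4 (beyond the scatter). This shows that the position on the anilino ring para to a large group is not indifferent to substitution, since one hydroxy, a single heavy atom, is enough to move the read-out at this dose by more than the usual scatter. The data offer no measurement that bears on why the number moves in this direction.

As far as these compounds go, whether a methoxy, a chlorine or an amine on the same aromatic carbon would move the number as hydroxy does remains open, and so does whether hydroxy on another carbon of that ring would do the same. Also open, from the compounds shown here alone, is whether the step would hold at other doses, as this read-out gives the size of the effect at one dose and not a potency.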